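The compounds below may be only part of what the source reports. "The series", "measured", "known", "first", "only" and "open" are said of these compounds alone.

In a functional assay on Huh-7 cells (Homo sapiens) for cytotoxicity, read by MTT assay, with a stated time of 3 days (on this read-out higher numbers stand for lower toxicity in this test and lower numbers for higher toxicity in this test), compound 1, `OC[C@H]1O[C@@H](n2cnc3c(CSCc4ccccc4)ncnc32)[C@H](O)[C@@H]1O`, gives only a limit of the test, > 100000 nM. Compound 2, `OC[C@H]1O[C@@H](n2cnc3c(Cn4ccc5ccccc54)ncnc32)[C@H](O)[C@@H]1O`, likewise reaches only a limit, > 250000 nM. Compound 3, `O=C(O)CSCc1ncnc2c1ncn2[C@@H]1O[C@H](CO)[C@@H](O)[C@H]1O`, again gives a limit rather than a number, > 100000 nM. So compound 3 cannot be placed on a scale: its value is a limit, and the two further values shown are limits too, two of the three values sitting at the limit of > 100000 nM in this assay, at which 2 of the 3 values shown sit, and the third at the limit of > 250000 nM in this assay, at which 1 of the 3 values shown sits. The steps a step that the two limits leave unreadable from compound 1 to compound 2, a step that the two limits leave unreadable from compound 1 to compound 3 and a step that the two limits leave unreadable from compound 2 to compound 3 are all left unreadable by these limits.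

Compound 4, `O=c1ccn(Cc2ncnc3c2ncn3[C@@H]2O[C@H](CO)[C@@H](O)[C@H]2O)cc1`, differs from compound 3 in that (a group of 7 heavy atoms (5 carbon, 1 nitrogen, 1 oxygen; one six-membered aromatic ring with 1 hetero atom) in place of a group of 5 heavy atoms (2 carbon, 2 oxygen, 1 sulfur; no ring), on a saturated chain carbon bound to an aromatic carbon). The two measured steps at the same place, a step that the two limits leave unreadable from compound 1 to compound 2 and a step that the two limits leave unreadable from compound 2 to compound 3, bear on this change, and neither has a readable size; nothing shown in this assay gives any direction or size to expect beyond the scatter. Compound 4 is therefore estimated to sit at a limit as well, about 100000 nM, in a range from 30000 nM to 300000 nM. Compound 4 is thus expected to show a step of a number no higher from compound 3 to compound 4 (the limit leaves the size open) that lies within the scatter.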

Compound 4, half-maximal cytotoxic concentration: > 100000 nM
Compound 4 ended at the assay's limit; the forecaster's own chance of this, stated with the estimate: 80%; the middle value sits exactly at the limit.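

In this assay compound 4 gives > 100000 nM as a limit and not a number. Its steps from compound 1, compound 2 and compound 3 therefore cannot be read. The compounds shown leave open at what concentration any of these four compounds becomes toxic in this test, and whether the groups compared differ in that toxicity at all.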